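Pentan-3-ylamino replaces cyclobutylamino on the shared core

A few compounds are considered here, and "the series" means these few. Any claim that something is new, unique, unknown or untested is made for them only; others in the source may bear on it.

Measured compounds:
compound 1 `CCN(CC)c1nc(C)nc2c(-c3c(C)cc(OC)cc3OC)c(C)nn12` — 1.2 nM
compound 2 `COc1cc(C)c(-c2c(C)nn3c(NC4CCC4)nc(C)nc23)c(OC)c1` — 17.4 nM

In an assay on cell membranes for displacement of a labelled ligand from corticotropin-releasing factor receptor 1 (Rattus norvegicus) (a lower number here means a stronger inhibitor, a higher number a weaker inhibitor), compound 1 gives 1.2 nM and compound 2 gives 17.4 nM. Going by the values given here, compound 2 stands at the higher of the two numbers; the only measured step, a 15-fold higher number from compound 1 to compound 2 (1.16 log units; beyond the scatter), separates it from compound 1 and is well beyond the scatter.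

Compound 3 `CCC(CC)Nc1nc(C)nc2c(-c3c(C)cc(OC)cc3OC)c(C)nn12` is not yet measured. It differs from compound 2 by pentan-3-yl in place of cyclobutyl on a nitrogen on an aromatic ring. The measured step that bears on this is a 15-fold higher number from compound 1 to compound 2 (1.16 log units; beyond the scatter): it shows that the group on this nitrogen is sensitive, a ring with four carbon atoms giving a much higher number than two open chains. Compound 3 returns to an open-chain group on the same nitrogen, though with one chain fewer on the nitrogen than compound 1. Among the compounds with values here, a move back toward the number of compound 1 is therefore expected, but not the full way, since no pair here isolates the effect of a secondary against a tertiary amine. The expected step is a 4.4-fold lower number from compound 2 to compound 3 (0.64 log units; beyond the scatter).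

For compound 3 the estimate in this assay is 4 nM, with a range from 1.5 nM to 15 nM.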

Compound 3, half-maximal inhibitory concentration: 5 nM
Compound 3: middle estimate off by 1.3-fold (0.10 log units), on the low side, and the stated range covers the measured number.
By their numbers in this assay, from the lowest: compound 1; then compound 3; then compound 2.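

In this assay, the comparison between compound 2 and compound 3 keeps a single carbon group on the nitrogen, and a 3.5-fold lower number from compound 2 to compound 3 (0.54 log units; beyond the scatter) shows that the group's identity matters even without the change from a doubly substituted amine: pentan-3-yl is preferred to cyclobutyl here. Diethylamino nonetheless remains ahead, with a 4.2-fold higher number from compound 1 to compound 3 (0.62 log units; beyond the scatter), so of the three groups on this position, the open-chain pentan-3-ylamino falls between diethylamino and cyclobutylamino, and an open-chain group alone does not recover the full number of compound 1. No supporting data are available to explain either step, so the ordering stands as an observation only.

The step from cyclobutyl to pentan-3-yl opens the ring and adds a carbon at once, so these compounds cannot separate the two changes; cyclopentylamino on the same nitrogen would bear directly on that question. As far as these compounds go, it also remains open whether diethylamino is near the best this position allows, or whether a longer chain, as in dipropylamino, would give a lower number than compound 1 on the shared core.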